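The compounds below may be only part of what the source reports. "The series", "measured", "known", "first", "only" and "open" are said of these compounds alone.

Measured so far in an assay on membranes from HeLa cells for displacement of a labelled ligand from adenosine receptor A3 (Homo sapiens), read by scintillation counting, with a stated time of 180 min, tested at 1 uM; a lower number here means less inhibition, a higher number more inhibition at the concentration tested (going by the name of the read-out):
compound 1, `CC1=C(C(=O)OC(C)(C)C)C(c2ccoc2)NC(=O)N1`: 2%
compound 2, `CC1=C(C(=O)OCc2ccccc2)C(c2ccoc2)NC(=O)N1`: 1%
compound 3, `CCNC(=O)C1=C(C)NC(=O)NC1c1ccoc1`: 1%

All three compounds sit at the bottom of the scale in this assay. Compound 3 is level with compound 2 at the digits given, and the two together are the lowest of the three numbers; compound 1 is the furthest from compound 3, yet the step of a number 1 percentage points lower from compound 1 to compound 3 (within the scatter) lies within the scatter, as does the step of a number 1 percentage points lower from compound 1 to compound 2 (within the scatter). Nothing among these three separates one compound from another beyond the noise of repeated measurement.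

The next compound is compound 4, `CC1=C(C(=O)OC2CCC2)C(c2ccoc2)NC(=O)N1`. It differs from compound 3 in one place: cyclobutyloxy in place of ethylamino on a carbonyl carbon. Among the compounds with values here, two measured steps bear on this. The step of a number 1 percentage points lower from compound 1 to compound 3 (within the scatter) exchanged the ester for the amide at the same carbonyl carbon and stayed within the scatter; the step of a number 1 percentage points lower from compound 1 to compound 2 (within the scatter) changed the group on the ester oxygen and also stayed within the scatter. Returning to an ester with a different ring-bearing group is therefore expected to leave the read-out where it was. Compound 4 is expected to give 2%, within -4% to 9%, which means an estimated step of a number 1 percentage points higher from compound 3 to compound 4 (within the scatter).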

Compound 4, a percentage reported as inhibition, at one concentration (the size of the read-out at that concentration, not a potency): 1%
Estimate against measurement, compound 4: 1 percentage points above; the measured number falls inside the stated range.
By their numbers in this assay, from the lowest: compounds 2, 3, 4 and 1 (each within the scatter of the next).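

In this assay, within the data shown here, cyclobutyloxy in place of ethylamino on a carbonyl carbon gave no change at the digits printed from compound 3 to compound 4 (within the scatter), so a one-place exchange that brings in a four-membered non-aromatic ring of carbon only, a ring type the earlier compounds did not carry, still separates nothing. On the oxygen next to the carbonyl group, cyclobutyl in place of benzyl gave no change at the digits printed from compound 2 to compound 4 (within the scatter), and cyclobutyl in place of tert-butyl gave a number 1 percentage points lower from compound 1 to compound 4 (within the scatter), so the three ester groups shown, one branched chain, one benzyl and one four-membered ring, cannot be told apart at this position. No measurement shown here offers an explanation for these numbers.

The compounds shown leave open whether a carboxylic acid on this carbonyl carbon, or an ester with a longer chain on the oxygen, would give a number that stands clear of the scatter around these four. With every number read at a single concentration, they also leave open whether these compounds would differ from one another at a higher concentration.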